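Methyl in Place of Chloro: Expected Cytotoxicity of Compound 3

This account rests on a few compounds, and the source may have more. Where it says the series, first, only, none or still open, it means among the compounds named here.

Measured so far:
Compound 1, `O=c1c(OCc2ccccc2[N+](=O)[O-])c(-c2ccccc2)oc2cc(O)cc(O)c12`: 51000 nM
Compound 2, `O=c1c(OCc2cccc(Cl)c2)c(-c2ccccc2)oc2cc(O)cc(O)c12`: 46000 nM

Both compounds were tested in an ADME assay on Huh-5-2 cells (Homo sapiens) for cytotoxicity, read by WST assay, with a stated time of 3 days; on this read-out lower numbers stand for higher toxicity in this test and higher numbers for lower toxicity in this test. Compound 2 carries the lower of the two numbers shown, but the step of a 1.1-fold lower number from compound 1 to compound 2 (0.04 log units; within the scatter) is within the scatter, so compound 2 and compound 1 cannot be told apart on this read-out.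

Compound 3, `Cc1cccc(COc2c(-c3ccccc3)oc3cc(O)cc(O)c3c2=O)c1`, is the next compound to be measured in this assay. It differs from compound 2 by methyl in place of chloro on an aromatic carbon. Going by the values given here, the only measured step that bears on this change is the one on the same benzyl group, from compound 1 to compound 2, which was within the scatter. On that basis no step beyond the scatter is expected in this assay.

Compound 3 is therefore expected to give about 46000 nM, in a range from 25000 nM to 85000 nM. The estimated step of no change at the digits printed from compound 2 to compound 3 (within the scatter) is expected to stay within the scatter.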

Compound 3, half-maximal cytotoxic concentration: 29000 nM
The estimate for compound 3 lay 1.6-fold (0.20 log units) above the measured number; the range from low to high includes it.
By their numbers in this assay, from the lowest: compounds 3, 2 and 1 (each within the scatter of the next).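

In this assay, methyl in place of chloro on this aromatic carbon gives a 1.6-fold lower number from compound 2 to compound 3 (0.20 log units; within the scatter), so the two groups cannot be told apart at this place on the ring. The wider comparison, with 3-methylphenyl in place of 2-nitrophenyl, gives a 1.8-fold lower number from compound 1 to compound 3 (0.25 log units; within the scatter), so the three benzyl variants shown, carrying nitro, chloro and methyl, all lie within the scatter of one another in this assay. No accompanying data bear on why these substituents give such similar numbers.

The compounds shown leave open whether an amine or a carboxylic acid on this aromatic carbon, or a longer chain in place of the methyl, would give a number beyond the scatter. They also leave open whether a change to the shared core, which all three carry unchanged, would do so.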